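Replacing piperidin-1-yl with methoxy in a short-lived series

The compounds below may be only part of what the source reports. "The series", "measured", "known", "first", "only" and "open" are said of these compounds alone.

In an ADME assay on microsomes from liver (Homo sapiens) for metabolic stability, read by LC-MS, using NADPH, with a stated time of 60 min, tested at 1 uM (on this read-out lower numbers stand for a shorter-lived compound and higher numbers for a longer-lived compound), compound 2 `O=[N+]([O-])c1ccccc1-c1ccc(CN2CCCC2c2ccc(N3CCCCC3)cc2)o1` gives 0.0325 h. This lies within the scatter of compound 1 `CN(C)c1ccc(C2CCCN2Cc2ccc(-c3ccccc3[N+](=O)[O-])o2)cc1` at 0.0423 h, whereas compound 3 `CN(C)c1cccc(C2CCCN2Cc2ccc(-c3ccccc3[N+](=O)[O-])o2)c1` reads lowest at 0.0095 h. Compound 4 `COc1ccc(C2CCCN2Cc2ccc(-c3ccccc3[N+](=O)[O-])o2)cc1` differs from compound 2 by methoxy in place of piperidin-1-yl on an aromatic carbon, with methoxy in place of piperidin-1-yl on an aromatic carbon. Among the compounds with values here, the closest evidence is a 1.3-fold lower number from compound 1 to compound 2 (0.11 log units; within the scatter), the only measured swap of the group at this place. The larger 4.5-fold lower number from compound 1 to compound 3 (0.65 log units; beyond the scatter) instead moves the group to another place on the ring, which this change does not do. No step beyond the scatter is therefore expected, and the estimated change is a 1.2-fold higher number from compound 2 to compound 4 (0.09 log units; within the scatter). Compound 4 is estimated at 0.04 h, with an expected range of 0.015 h to 0.1 h.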

Compound 4, half-life: 0.0183 h
Estimate against measurement, compound 4: 2.2-fold (0.34 log units) above; the measured number falls inside the stated range.
By their numbers in this assay, from the lowest: compounds 3, 4, 2 and 1 (each within the scatter of the next, the first and the last beyond it).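

In this assay, methoxy on this aromatic carbon gives a 1.8-fold lower number from compound 2 to compound 4 (0.25 log units; within the scatter), so it cannot be told apart from piperidin-1-yl. Against dimethylamino, the same place shows a 2.3-fold lower number from compound 1 to compound 4 (0.36 log units; beyond the scatter), the first swap of the group here to pass the scatter, though only modestly. The step involving the 3-(dimethylamino)phenyl compound, a 1.9-fold higher number from compound 3 to compound 4 (0.28 log units; within the scatter), also stays inside the scatter.

Nothing shown explains these numbers. Open, as far as these compounds go, is whether a fluorine atom or a carboxylic acid at this place would give a longer half-life than any of these groups.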